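Ring-amine methyl removal across two fused sulfonamide cores

A few compounds are considered here, and "the series" means these few. Any claim that something is new, unique, unknown or untested is made for them only; others in the source may bear on it.

Of the compounds shown here, three of one aryl sulfonamide theme have been measured in an assay on isolated protein for displacement of a labelled ligand from 5-hydroxytryptamine receptor 6 (Homo sapiens), read by radioligand binding; on this read-out lower numbers stand for stronger inhibition and higher numbers for weaker inhibition. Compound 3 `CCCCc1ccc(S(=O)(=O)Nc2ccc3c(c2)CCN(C)CC3)cc1` gives 1.26 nM. Compound 1 `CCCCc1ccc(S(=O)(=O)Nc2ccc3c(c2)CCNCC3)cc1` gives 2 nM in this assay; the step of a 1.6-fold higher number from compound 3 to compound 1 (0.20 log units; within the scatter) corresponds to the change (hydrogen in place of methyl on an amine nitrogen in a ring). Compound 2 `CCCCc1ccc(S(=O)(=O)Nc2ccc3c(c2)CN(C)C3)cc1` gives 5.01 nM in this assay; the difference between the core of compound 2 and the core of compound 3 is not broken down here. Compound 2 shows the highest of the three numbers, with compound 1 nearer to it than compound 3.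

Compound 4 `CCCCc1ccc(S(=O)(=O)Nc2ccc3c(c2)CNC3)cc1` is not yet measured. It arises from compound 2 by hydrogen in place of methyl on an amine nitrogen in a ring. Among the measured compounds shown here, this is the same kind of change as the one made from compound 3 to compound 1, not the same: there the amine nitrogen sits in a seven-membered non-aromatic ring with 1 nitrogen, here in a five-membered non-aromatic ring with 1 nitrogen, both part of a fused or bridged system of two rings. For the measured compounds named here, only one instance of the change is measured, so the expectation rests on that single step alone. Because the measured instance came out as a 1.6-fold higher number from compound 3 to compound 1 (0.20 log units; within the scatter), compound 4 is expected to show about a 1.6-fold higher number from compound 2 to compound 4 (0.20 log units; within the scatter) in this assay. The estimate for compound 4 in this assay is 8 nM, between 3 nM and 20 nM.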

Compound 4, inhibition constant: 50.1 nM
Beside the measured number, compound 4's estimate is 6.3-fold (0.80 log units) below it, and the stated range ends below it.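

In this assay, replacing the methyl on the ring amine nitrogen with hydrogen gives a 10-fold higher number from compound 2 to compound 4 (1.00 log units; beyond the scatter). The size of this change therefore does not carry from one core to the other in this series: the same change on two cores in this assay, a 1.6-fold higher number (0.20 log units; within the scatter) from compound 3 to compound 1 and a 10-fold higher number (1.00 log units; beyond the scatter) from compound 2 to compound 4, 6.3-fold (0.80 log units) apart, beyond the scatter of two such steps. Two pairs set no rule for other cores, and they do not show what in the core accounts for the gap.

The compounds shown leave open whether the gap between the two cores persists with a larger group than methyl on the ring nitrogen, such as ethyl or isopropyl. On these data alone, all four compounds also share the butyl chain, so it remains open whether the same gap appears when a shorter chain or a chlorine takes its place.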